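The source may report more compounds than this note shows. Statements on the series, on what has been measured and on what is new or still open speak of the compounds shown alone.

Measured so far in an ADME assay on the whole organism (plasma, strain ICR) for pharmacokinetics, with Mus musculus as the target, with a stated time of 8 h, at a dose of 20 mg/kg by the intravenous route; on this read-out higher numbers stand for higher exposure at the dose given and lower numbers for lower exposure:
- compound 1 `FC(F)(F)c1ccc(Oc2ccc(-c3noc(-c4c[nH]cn4)n3)cc2)cc1` gives 34200 ng.h/mL
- compound 2 `C#Cc1c[nH]nc1-c1nc(-c2ccc(Oc3ccc(C(F)(F)F)cc3)cc2)no1` gives 138000 ng.h/mL

Among the measured compounds shown here, compound 2 holds the higher of these two numbers; the single measured step, a 4.0-fold higher number from compound 1 to compound 2 (0.61 log units; beyond the scatter), concerns a different change on the same core. Compound 3 `CC(C)Nc1c[nH]nc1-c1nc(-c2ccc(Oc3ccc(C(F)(F)F)cc3)cc2)no1` differs from compound 2 by isopropylamino in place of ethynyl on an aromatic carbon. For the measured compounds named here, no measured step covers this swap, so in this assay no change beyond the scatter is expected. Compound 3 is therefore estimated at 100000 ng.h/mL, between 40000 ng.h/mL and 250000 ng.h/mL, an expected step of a 1.4-fold lower number from compound 2 to compound 3 (0.14 log units; within the scatter).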

Compound 3, area under the concentration-time curve: 21900 ng.h/mL
For compound 3 the middle estimate is 4.6-fold (0.66 log units) above the measured one; measured number outside the range, below it.
By their numbers in this assay, from the lowest: compounds 3 and 1 (each within the scatter of the next); then compound 2.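

In this assay, the group on this aromatic carbon of the five-membered ring with 2 nitrogen clearly affects the read-out: isopropylamino in place of ethynyl gives a 6.3-fold lower number from compound 2 to compound 3 (0.80 log units; beyond the scatter). Replacing 1H-imidazol-4-yl with 4-(isopropylamino)-1H-pyrazol-3-yl gives a 1.6-fold lower number from compound 1 to compound 3 (0.19 log units; within the scatter), so the higher exposure seen with the ethynyl compound is not shared by this amine. No measurement here explains the drop. Still open, going by these compounds, is how a primary amine, a dimethylamino group or a nitrile at this carbon would compare with ethynyl and isopropylamino.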